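The source may hold more compounds than are shown below. What is called first, only, known or untested is meant among the compounds shown, and "the series" means these compounds.

Compound 1 `N/C(=N\NC(=S)N1CCOCC1)c1ccccn1` is the reference point of this small set. In a functional assay on A-431 cells (Homo sapiens) for cytotoxicity, read by MTT assay, with a stated time of 72 h (on this read-out higher numbers stand for weaker inhibition and lower numbers for stronger inhibition), compound 1 gives 4800 nM, and neither companion compound is separated from it beyond the scatter. Compound 2 `Cc1ccnc(/C(N)=N/NC(=S)N2CCOCC2)c1` gives 6800 nM, and compound 3 `N/C(=N\NC(=S)N1CCSCC1)c1ccccn1` gives 6700 nM. The two measured steps are a 1.4-fold higher number from compound 1 to compound 2 (0.15 log units; within the scatter) and a 1.4-fold higher number from compound 1 to compound 3 (0.14 log units; within the scatter), both within the scatter.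

Compound 4 `Cc1cccc(/C(N)=N/NC(=S)N2CCOCC2)n1` differs from compound 1 by methyl in place of hydrogen on an aromatic carbon. For the measured compounds named here, the step that bears most directly on it is the one from compound 1 to compound 2, where a methyl also entered an aromatic carbon of the same ring, though at a different place; that step was a 1.4-fold higher number from compound 1 to compound 2 (0.15 log units; within the scatter). Going by the values given here, no step in this set moved the numbers beyond the scatter, so for compound 4 the expected step in this assay is none beyond the scatter, that is a 1.1-fold higher number from compound 1 to compound 4 (0.06 log units; within the scatter). Compound 4 is therefore estimated to give 5500 nM, with a range from 2800 nM to 11000 nM.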

Compound 4, half-maximal inhibitory concentration: 4300 nM
Beside the measured number, compound 4's estimate is 1.3-fold (0.11 log units) above it; the measured number falls inside the stated range.
By their numbers in this assay, from the lowest: compounds 4, 1, 3 and 2 (each within the scatter of the next).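

Methyl in place of hydrogen, on the aromatic carbon next to the ring nitrogen and meta to a large group, gives a 1.1-fold lower number from compound 1 to compound 4 (0.05 log units; within the scatter) in this assay. Read with a 1.4-fold higher number from compound 1 to compound 2 (0.15 log units; within the scatter), it shows that methyl at either of these two different places on the ring leaves the number within the scatter of compound 1, so this set separates neither place from hydrogen or from the other. Nothing measured here explains why this position shows no change beyond the scatter.

The compounds shown leave open whether a group other than methyl at this place, such as an amine, a methoxy group, a carboxylic acid or a longer chain, would move the number beyond the scatter. They also leave open whether the same methyl would behave alike on compound 3, which carries thiomorpholin-4-yl in place of morpholin-4-yl.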